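The compounds below may be only part of what the source reports. "The series", "measured", "known", "first", "only" and "open" are said of these compounds alone.

In an assay on HeLa cells for inhibition of Indoleamine 2,3-dioxygenase 1 (Homo sapiens), read by spectrophotometry, with a stated time of 24 h (on this read-out lower numbers stand for an effect already at smaller amounts and higher numbers for an effect only at larger amounts of compound), compound 3 `N#Cc1ccc(S(=O)(=O)NNc2ccc(Br)cc2)cc1` gives 134 nM. Compound 1 `O=S(=O)(NNc1ccc(Br)cc1)c1ccccc1` gives 128 nM in this assay, a number within the usual scatter of compound 3, while compound 2 `O=S(=O)(NNc1ccc(Br)cc1)c1ccc(Br)cc1` gives 374 nM. Compound 4 `COC(=O)CCc1ccc(S(=O)(=O)NNc2ccc(Br)cc2)cc1` differs from compound 3 in one place: 2-(methoxycarbonyl)ethyl in place of cyano on an aromatic carbon. Three measured steps change the group on that same aromatic carbon: a 2.9-fold higher number from compound 1 to compound 2 (0.47 log units; beyond the scatter), a 1.0-fold higher number from compound 1 to compound 3 (0.02 log units; within the scatter), and a 2.8-fold lower number from compound 2 to compound 3 (0.45 log units; beyond the scatter). Each was modest or within the scatter, but none introduced a chain like the 2-(methoxycarbonyl)ethyl group, so the outcome is uncertain; a modest shift in either direction is expected, a 1.5-fold higher number from compound 3 to compound 4 (0.17 log units; within the scatter). Compound 4 is therefore estimated at 200 nM in this assay, within a range from 70 nM to 600 nM.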

Compound 4, half-maximal effective concentration: 465 nM
For compound 4 the middle estimate is 2.3-fold (0.37 log units) below the measured one; low and high end bracket the measured number.
By their numbers in this assay, from the lowest: compounds 1 and 3 (each within the scatter of the next); then compounds 2 and 4 (each within the scatter of the next).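

At this aromatic carbon, the 2-(methoxycarbonyl)ethyl chain gives a 3.5-fold higher number from compound 3 to compound 4 (0.54 log units; beyond the scatter) and a 3.6-fold higher number from compound 1 to compound 4 (0.56 log units; beyond the scatter) in this assay. Against bromo, the same chain gives a 1.2-fold higher number from compound 2 to compound 4 (0.09 log units; within the scatter), so a chain and a single bromo atom cannot be told apart here. Nothing available explains this result.

On these data alone, it remains open whether the chain's length or its ester end matters more. A plain propyl chain or the matching carboxylic acid at this carbon could help separate the two.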